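Swapping cyclohexyl for pyridinylsulfanyl on the acylguanidine core

This account rests on a few compounds, and the source may have more. Where it says the series, first, only, none or still open, it means among the compounds named here.

Measured compounds:
compound 1, `Cc1c(C(=O)N=C(N)N)ccc(Cl)c1S(C)(=O)=O`: 1300 nM
compound 2, `Cc1cc(C2CCCCC2)c(S(C)(=O)=O)cc1C(=O)N=C(N)N`: 22 nM
compound 3, `Cc1c(C(=O)N=C(N)N)cc(S(C)(=O)=O)c(C)c1C`: 55 nM

The three compounds were tested in a functional assay for inhibition of sodium/hydrogen exchanger (Oryctolagus cuniculus); a higher number here means a weaker inhibitor, a lower number a stronger inhibitor. Compound 1 gives 1300 nM, compound 3 gives 55 nM, and compound 2 gives 22 nM, the lowest of the three numbers. Its nearest neighbour is compound 3, whose number is higher by an amount beyond the scatter, and compound 1 lies furthest away, also beyond the scatter. Compound 2 is therefore the strongest inhibitor among the three in this assay.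

The step now considered leads from compound 2 to compound 4, `Cc1cc(Sc2ccncc2)c(S(C)(=O)=O)cc1C(=O)N=C(N)N`, which has not yet been measured. The change is (pyridin-4-yl)sulfanyl in place of cyclohexyl on an aromatic carbon. The cyclohexyl group of compound 2 gives way to a group carrying two hydrogen-bond acceptors and one hetero atom in an aromatic ring, on the same aromatic carbon ortho to the methylsulfonyl group.

Within the data shown here, no measured pair shows this change, so the direction of the step is uncertain. Since compound 2 gives 22 nM, compound 4 is expected to stay in the same region, with a modest loss of potency considered somewhat more likely than a gain; the expected step is a 2.7-fold higher number from compound 2 to compound 4 (0.44 log units; beyond the scatter). Compound 4 is estimated at 60 nM, within a range from 15 nM to 250 nM.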

Compound 4, half-maximal inhibitory concentration: 13 nM
Beside the measured number, compound 4's estimate is 4.6-fold (0.66 log units) above it; the measured number lies below the stated range.
By their numbers in this assay, from the lowest: compounds 4 and 2 (each within the scatter of the next); then compound 3; then compound 1.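

In this assay, placing (pyridin-4-yl)sulfanyl instead of cyclohexyl on the aromatic carbon ortho to a methylsulfonyl group gives a 1.7-fold lower number from compound 2 to compound 4 (0.23 log units; within the scatter), so this change leaves the number unresolved from that of the starting compound. Among these compounds, this position therefore accepts a six-membered aromatic ring with a hetero atom, joined through sulfur and carrying hydrogen-bond acceptors, as well as a six-membered non-aromatic ring of carbon only with no such acceptors, which the earlier compounds, with no single-place step among them, could not show. No evidence on the cause of this result is available.

Going by these compounds, it remains open whether the sulfur link or the pyridin-4-yl ring matters more, which a phenylsulfanyl group or a directly attached pyridin-4-yl group could separate. Also open, on these data alone, is how an amine or a carboxylic acid on this carbon would behave in this assay.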